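Dihydroxyphenyl in place of dichlorophenyl on compound 3

A few compounds are considered here, and "the series" means these few. Any claim that something is new, unique, unknown or untested is made for them only; others in the source may bear on it.

Three compounds were tested in a functional assay on MCF7 cells (Homo sapiens) for cytotoxicity, read by MTT assay, with a stated time of 48 h; on this read-out lower numbers stand for stronger inhibition and higher numbers for weaker inhibition. Compound 1 `COc1ccc(C(=O)CSC(=S)Nc2cc(OC)c(OC)c(OC)c2)cc1` gave 18.6 ug/mL, compound 2 `COc1cc(N2C(=S)SCC2(O)c2ccc(Br)cc2)cc(OC)c1OC` gave 16.5 ug/mL, and compound 3 `COc1cc(-n2c(-c3ccc(Cl)cc3Cl)csc2=S)cc(OC)c1OC` gave 23.6 ug/mL. Compound 3 thus carries the highest number of the three, but its gaps to compound 1 and to compound 2 both fall within the usual scatter, so no ranking among them can be read. Compound 4 `COc1cc(-n2c(-c3ccc(O)c(O)c3)csc2=S)cc(OC)c1OC` has not yet been measured in this assay; it differs from compound 3 by 3,4-dihydroxyphenyl in place of 2,4-dichlorophenyl on an aromatic carbon. Among the measured compounds shown here, no measured pair shows this change, and the estimate therefore rests only on compound 3 at 23.6 ug/mL. Compound 4 is expected to give about 30 ug/mL, within a range of 12 ug/mL to 80 ug/mL, which means an estimated step of a 1.3-fold higher number from compound 3 to compound 4 (0.10 log units; within the scatter) that is small and not clearly beyond the scatter.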

Compound 4, half-maximal inhibitory concentration: > 100 ug/mL
Compound 4 gave a limit, no number (the forecaster's own chance of this, stated with the estimate: 10%); middle value at least 3.3-fold (0.52 log units) from the limit.
By their numbers in this assay, from the lowest: compounds 2, 1 and 3 (each within the scatter of the next). At a limit, above all of these: compound 4.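

In this assay, this position on the shared core proves sensitive to the group it carries: 3,4-dihydroxyphenyl in place of 2,4-dichlorophenyl gives an at least 4.2-fold higher number from compound 3 to compound 4 (0.62 log units; beyond the scatter). For compound 4 the read-out is a limit, not a number, so the step has only a lower bound: the limit of > 100 ug/mL in this assay, at which 1 of the 4 values shown sits.

The change replaces chlorine with hydroxyl and alters the substitution pattern at once, so the compounds shown do not separate these two differences. From the compounds shown here alone, it remains open whether a phenyl bearing a single hydroxyl, a methoxy group or an amine here would give a measurable number.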